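Swapping a Side Chain Where Every Reading Is a Limit

The source may hold more compounds than are shown below. What is called first, only, known or untested is meant among the compounds shown, and "the series" means these compounds.

In an ADME assay on MCF-10A cells (Homo sapiens) for antiproliferative activity, read by MTT assay, with a stated time of 72 h (on this read-out lower numbers stand for stronger inhibition and higher numbers for weaker inhibition), three compounds have been tested so far, and none has yet given an exact number. Compound 1 (`CN1CCN(C(=S)SSC(=S)N2CCN(C)CC2)CC1`) reads > 10000 nM, which is a limit of the assay. Compound 2 (`CCN(CC)C(=S)SSCCO`) reads > 10000 nM, also a limit. Compound 3 (`CCCCCCSSC(=S)N(CC)CC`) reads > 10000 nM, again a limit. Compound 2 therefore has no exact place in the series, and the whole set shares one reading: the limit of > 10000 nM in this assay, at which 3 of the 3 values shown sit.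

Compound 4 (`CCC(C)SSC(=S)N(CC)CC`) is still unmeasured. It differs from compound 2 by having sec-butyl in place of 2-hydroxyethyl on a sulfur. Among the compounds with values here, the one measured step that bears on this change also removes the hydroxy, putting butyl in its place: a step that the two limits leave unreadable from compound 2 to compound 3. That step has no readable size to carry over, but its end point is still a limit. Compound 4 is therefore expected to stay in the same region of this assay, with no step beyond the usual scatter and no direction favoured. The expected step is a step that the limit leaves unreadable from compound 2 to compound 4. For compound 4 the estimated value is 15000 nM, with an expected range from 7000 nM to 40000 nM.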

Compound 4, half-maximal inhibitory concentration: > 10000 nM
Compound 4: only a limit was reported; the forecaster's own chance of this, stated with the estimate: 85%; the middle value lies beyond the limit too.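

Compound 4 reads > 10000 nM, which is a limit of the assay. No size can therefore be read for the step from compound 2 to compound 4. The compounds shown leave open the exact value of each one and whether changing the side chain alters activity at all, because all the readings are the same: the limit of > 10000 nM in this assay, at which 4 of the 4 values shown sit.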